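Series notes: the step from compound 3 to compound 4

The source may report more compounds than this note shows. Statements on the series, on what has been measured and on what is new or still open speak of the compounds shown alone.

Measured in an ADME assay on MDCK cells (Canis lupus familiaris) for cytotoxicity; on this read-out lower numbers stand for higher toxicity in this test and higher numbers for lower toxicity in this test:
- Compound 1 `CC(=O)Nc1ccc2oc(-c3ccnc(C(=O)N4CC5CC4CN5C(c4ccccc4)c4nnn(C)n4)c3)nc2c1`: > 50000 nM, a limit
- Compound 2 `CC(=O)Nc1ccc2oc(-c3ccnc(C(=O)N4CCC5(CC4)CN(C(c4ccccc4)c4nnn(C)n4)C5)c3)nc2c1`: > 50000 nM, a limit
- Compound 3 `CC(=O)Nc1ccc2oc(-c3ccnc(C(=O)N4CCN(C(c5cccc(F)c5)c5nnn(C)n5)CC4)c3)nc2c1`: > 50000 nM, a limit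

Compound 3 stands at the limit of > 50000 nM in this assay, at which 3 of the 3 values shown sit. For the measured compounds named here, no compound yet has a number, so no step between them can be read.

Compound 4 `CC(=O)Nc1ccc2oc(-c3ccnc(C(=O)N4CCN(C(c5ccc(Cl)cc5)c5nnn(C)n5)CC4)c3)nc2c1` differs from compound 3 as follows: 4-chlorophenyl in place of 3-fluorophenyl on a saturated chain carbon bound to an amine nitrogen in a ring and an aromatic carbon. In words, this is 4-chlorophenyl in place of 3-fluorophenyl on a saturated chain carbon bound to an amine nitrogen in a ring and an aromatic carbon.

Little change is expected in this assay because compound 3 sits at > 50000 nM, which is a limit. The expected size of the change is a number no higher from compound 3 to compound 4 (the limit leaves the size open). For compound 4 the estimate is 50000 nM, with an expected range of 25000 nM to 50000 nM.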

Compound 4, half-maximal cytotoxic concentration: > 50000 nM
Compound 4 ended at the assay's limit; the forecaster's own chance of this, stated with the estimate: 80%; the middle value lies on the limit itself.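

No step can be read between compound 3 and compound 4 in this assay, as each value is a limit: the limit of > 50000 nM in this assay, at which 4 of the 4 values shown sit.

The compounds shown leave open what number any of the four would carry, and whether 4-chlorophenyl in place of 3-fluorophenyl changes the read-out at all.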